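From nitro to chloro with one measured value

A few compounds are considered here, and "the series" means these few. Any claim that something is new, unique, unknown or untested is made for them only; others in the source may bear on it.

compound 1 `CC(C)CN(C)Cc1ccc(C2=CCCN(C)C2)cc1`: "not determined" (no result reported)
compound 2 `CN1CCC=C(c2ccc(CN(C)Cc3ccccc3)cc2)C1`: "not determined" (no result reported)
compound 3 `CN1CCC=C(c2ccc(CN(C)Cc3ccc([N+](=O)[O-])cc3)cc2)C1`: 2290 nM

For the measured compounds named here, in a functional assay on HL-60 cells (Homo sapiens) for inhibition (a higher number here means a weaker inhibitor, a lower number a stronger inhibitor), compound 3 gives 2290 nM as the only number available, so it cannot be ranked against any other compound. Neither compound 1 nor compound 2 offers a comparison. Compound 4 `CN1CCC=C(c2ccc(CN(C)Cc3ccc(Cl)cc3)cc2)C1` differs from compound 3 in one place, with chloro in place of nitro on an aromatic carbon, para to a large group: chloro in place of nitro on an aromatic carbon is the whole change. Going by the values given here, no measured step shows what this swap does, so the expectation rests on compound 3 at 2290 nM alone. The expected 1.1-fold lower number from compound 3 to compound 4 (0.06 log units; within the scatter) is small, and no shift beyond the scatter is expected in either direction. For compound 4 the estimated value is 2000 nM with an expected range from 700 nM to 6000 nM around it.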

Compound 4, half-maximal inhibitory concentration: 2140 nM
The estimate for compound 4 lay 1.1-fold (0.03 log units) below the measured number, and the stated range covers the measured number.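

In this assay, chloro in place of nitro on the aromatic carbon, para to a large group, gives a 1.1-fold lower number from compound 3 to compound 4 (0.03 log units; within the scatter). At this position, the two groups therefore cannot be told apart, although chloro has no hydrogen-bond acceptors and nitro has two. Nothing measured here explains this result.

Steps involving compound 1 or compound 2 cannot be read, so the effect of having no group at this position stays unknown. From the compounds shown here alone, whether an amine or a carboxylic acid here would shift the number beyond the scatter also remains open.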